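The source may hold more compounds than are shown below. What is called first, only, known or untested is meant among the compounds shown, and "the series" means these compounds.

The set comprises three measured compounds and one awaiting measurement. Compound 1 `Cc1ccccc1Cc1ccc(N2CCC[C@H]2CC(=O)O)cc1` is the parent; compound 2 `Cc1ccccc1Cc1ccc(N2C[C@@H](C(F)(F)F)C[C@H]2CC(=O)O)cc1` carries a trifluoromethyl on its saturated ring, and compound 3 `COc1ccc(F)c(-c2ccc(Cc3ccc(N4CCC[C@H]4CC(=O)O)cc3)c(C)c2)c1` carries a 2-fluoro-5-methoxyphenyl on an aromatic carbon. In a functional assay on cells for agonist activity at Free fatty acid receptor 1 (Homo sapiens), read by FLIPR and calcium flux, with a stated time of 100 s (a higher number here means that more compound is needed for the effect, a lower number that less compound is needed), compound 1 gives 150 nM, compound 2 gives 67 nM, and compound 3 gives 220 nM. Compound 3 thus shows the highest of the three numbers; against compound 1 the gap is within the scatter, the step being a 1.5-fold higher number from compound 1 to compound 3 (0.17 log units; within the scatter), whereas against compound 2 the gap is beyond the scatter, as the two values show.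

Compound 4 `COc1ccc(F)c(-c2ccc(Cc3ccc(N4C[C@@H](C(F)(F)F)C[C@H]4CC(=O)O)cc3)c(C)c2)c1` differs from compound 3 by trifluoromethyl in place of hydrogen on a saturated ring carbon. The same change has been made once before, on the parent, where it gave a 2.2-fold lower number from compound 1 to compound 2 (0.35 log units; beyond the scatter). Among the compounds with values here, that is the only step bearing directly on this change, and it suggests a modest lowering of the number. The other step, a 1.5-fold higher number from compound 1 to compound 3 (0.17 log units; within the scatter), concerns the aromatic substituent and is within the scatter, so it neither supports nor contradicts a carry-over.

Compound 4 is therefore expected to give about 100 nM in this assay, within a range of 40 nM to 250 nM. For the step this would mean an expected 2.2-fold lower number from compound 3 to compound 4 (0.34 log units; beyond the scatter).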

Compound 4, half-maximal effective concentration: 490 nM
Estimate against measurement, compound 4: 4.9-fold (0.69 log units) below; measured number outside the range, above it.
By their numbers in this assay, from the lowest: compound 2; then compounds 1 and 3 (each within the scatter of the next); then compound 4.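

In this assay, trifluoromethyl in place of hydrogen on this saturated ring carbon, two ring bonds from the ring nitrogen, now gives a 2.2-fold higher number from compound 3 to compound 4 (0.35 log units; beyond the scatter), so the direction of the change does not carry over from one core to the other: the same change on two cores in this assay, a 2.2-fold lower number (0.35 log units; beyond the scatter) from compound 1 to compound 2 and a 2.2-fold higher number (0.35 log units; beyond the scatter) from compound 3 to compound 4, 5.0-fold (0.70 log units) apart, beyond the scatter of two such steps Read from the other side, the 2-fluoro-5-methoxyphenyl group, whose step on the parent stays within the scatter, gives a 7.3-fold higher number from compound 2 to compound 4 (0.86 log units; beyond the scatter) once the trifluoromethyl is present: the same change on two cores in this assay, a 1.5-fold higher number (0.17 log units; within the scatter) from compound 1 to compound 3 and a 7.3-fold higher number (0.86 log units; beyond the scatter) from compound 2 to compound 4, 5.0-fold (0.70 log units) apart, beyond the scatter of two such steps In these four compounds the two changes therefore do not add up independently, as the effect of each depends on what the other place carries, which the steps from compound 1 alone could not show.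

As far as these compounds go, it remains open whether this reversal belongs to trifluoromethyl as such or would also appear with a methyl group or a single fluorine on the same ring carbon. From the compounds shown here alone, it is equally open whether it needs the whole 2-fluoro-5-methoxyphenyl group or would also arise with a plain phenyl group, and the four values give no reason for the dependence.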